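Testing the mirror image of compound 2

The compounds below may be only part of what the source reports. "The series", "measured", "known", "first", "only" and "open" are said of these compounds alone.

Measured so far in a functional assay on SW480 cells (Homo sapiens) for cytotoxicity, read by MTT assay, with a stated time of 48 h; a higher number here means a weaker inhibitor, a lower number a stronger inhibitor:
- Compound 1 `CCOC(=O)[C@@]1(C(=O)Nc2ccccc2Cl)C[C@@H]1c1cc(OC)c(OC)c(OC)c1` gives 46700 nM
- Compound 2 `CCOC(=O)[C@]1(C(=O)NCc2ccc(C)cc2)C[C@H]1c1cc(OC)c(OC)c(OC)c1` gives 36400 nM

Compound 2 (36400 nM) stands level with compound 1, since the two values lie within the usual scatter of repeated measurements and cannot be ranked.

Compound 3 `CCOC(=O)[C@@]1(C(=O)NCc2ccc(C)cc2)C[C@@H]1c1cc(OC)c(OC)c(OC)c1` has not yet been measured. Compared with compound 2, nothing leaves and nothing enters (the two compounds have the same atoms and bonds and differ only in configuration as drawn: 2 of 2 stereo elements differ (all stereocentres are inverted: mirror images); a stereocentre at a saturated ring carbon is drawn R in compound 2 and S in compound 3; a stereocentre at a saturated ring carbon is drawn S in compound 2 and R in compound 3). The two compounds have the same atoms and bonds and are mirror images. The stereocentre at a saturated ring carbon drawn R in compound 2 is drawn S in compound 3, and the one drawn S is drawn R.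

Within the data shown here, no mirror-image pair has been measured here, so the data give no direct guide to the size of this step. The expectation therefore rests on compound 2 (36400 nM), with no shift beyond the scatter in either direction and a wide range to allow for surprise. The expected change is small (a 1.0-fold higher number from compound 2 to compound 3 (0.02 log units; within the scatter)). For compound 3 the estimated value is 38000 nM (expected range 15000 nM to 90000 nM).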

Compound 3, half-maximal inhibitory concentration: > 100000 nM
Compound 3: a limit, no number; the forecaster's own chance of this, stated with the estimate: 15%; at least 2.6-fold (0.42 log units) between middle value and limit.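

In this assay compound 3 gives > 100000 nM, which is a limit of the assay and not a number. Among these compounds, the mirror-image change alone gives an at least 2.7-fold higher number from compound 2 to compound 3 (0.43 log units; beyond the scatter), so the earlier compounds' silence on stereochemistry now gives way to a first sign that configuration at the two saturated ring carbons matters for this cytotoxicity, with no atom or bond altered: the fact that compounds 2 and 3 differ only in the configuration as drawn. Within the configuration shared by compound 1 and compound 3, placing 4-methylbenzyl in place of 2-chlorophenyl on the amide-type nitrogen gives an at least 2.1-fold higher number from compound 1 to compound 3 (0.33 log units; beyond the scatter), which shows that the group on this nitrogen also matters, although the limit again hides the full size of the step.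

Going by these compounds, how far compound 3 truly lies from the other two stays unknown, and so does whether the mirror image of compound 1 would show a similar loss. Also open, on these data alone, is how either configuration would respond if a carboxylic acid replaced the ethyl ester, or if a longer chain joined the amide nitrogen to its aromatic ring.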